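Benzoyl to phenylcarbamoyl on the pyridinium nitrogen

A few compounds are considered here, and "the series" means these few. Any claim that something is new, unique, unknown or untested is made for them only; others in the source may bear on it.

The series shares one core, shown in compound 1 `N#Cc1ccc2c(c1)C(c1cccc[n+]1[O-])=CC(CF)(CF)O2`, which in a functional assay (aorta) with Rattus norvegicus as the target (on this read-out higher numbers stand for an effect only at larger amounts of compound and lower numbers for an effect already at smaller amounts), gives 16.6 nM. Compound 2 `O=[N+]([O-])c1ccc2c(c1)C(c1cccc[n+]1[O-])=CC(CF)(CF)O2` gives 1.74 nM in this assay, and the step of a 9.5-fold lower number from compound 1 to compound 2 (0.98 log units; beyond the scatter) is the nitro in place of cyano on an aromatic carbon. Compound 3 `O=C([N-][n+]1ccccc1C1=CC(CF)(CF)Oc2ccc([N+](=O)[O-])cc21)c1ccccc1` carries a benzoyl group on the aromatic nitrogen in place of the oxygen atom of compound 2. In this assay the value of compound 3 is only a limit, < 10000 nM, so compound 3 stands at the limit of < 10000 nM in this assay, at which 1 of the 3 values shown sits, and not at a number. The step that the limit leaves unreadable from compound 2 to compound 3 therefore cannot be sized.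

Compound 4 `O=C([N-][n+]1ccccc1C1=CC(CF)(CF)Oc2ccc([N+](=O)[O-])cc21)Nc1ccccc1` differs from compound 3 in one place: anilino in place of phenyl on a carbonyl carbon, or benzoyl to phenylcarbamoyl. For the measured compounds named here, no measured step touches this part of the molecule; the only readable step, from compound 1 to compound 2, sits on the aromatic carbon and does not bear on it, and the step into compound 3 is unreadable. The expectation for compound 4 is thus uncertain, with a step that the limit leaves unreadable from compound 3 to compound 4 expected only as a broad guess. Compound 4 is estimated at 500 nM, within 20 nM to 10000 nM, in this assay.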

Compound 4, half-maximal effective concentration: 9120 nM
Compound 4: the middle estimate sits 18-fold (1.26 log units) below what was measured; measured number inside the range.
By their numbers in this assay, from the lowest: compound 2; then compound 1; then compound 4.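

At the aromatic nitrogen the series now has a size: in this assay, putting the phenylcarbamoyl-bearing group in place of the oxygen atom is a 5200-fold higher number from compound 2 to compound 4 (3.72 log units; beyond the scatter). That large step outweighs the modest one on the aromatic carbon, a 9.5-fold lower number from compound 1 to compound 2 (0.98 log units; beyond the scatter), so among the compounds shown, what sits on this nitrogen moves the number much further than the change from cyano to nitro. The comparison of the two groups on the carbonyl carbon, and every other step into or out of compound 3, cannot be read, because the value of compound 3 is only a limit: the limit of < 10000 nM in this assay, at which 1 of the 4 values shown sits.

On these data alone, whether the hydrogen-bond donor that anilino brings makes any difference therefore stays open, since compound 3 gives no number to set against compound 4. The compounds shown also leave open whether a much smaller group on the carbonyl carbon, such as methyl or methoxy, would hold the number closer to that of compound 2, and whether the large step would look the same with cyano on the aromatic carbon in place of nitro.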